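Enlarging the ketone side chain of compound 3

A few compounds are considered here, and "the series" means these few. Any claim that something is new, unique, unknown or untested is made for them only; others in the source may bear on it.

Of the compounds shown here, three sharing one core have been measured in an assay on HEK293 cells for positive allosteric modulation of metabotropic glutamate receptor 2 (Rattus norvegicus), read by thallium flux, with a stated time of 2.5 min; a lower number here means that less compound is needed, a higher number that more compound is needed for the effect. Compound 1 `Cc1c(OCCCCOc2ccc(C(=O)O)cc2Cl)ccc(C(=O)CC2CCCC2)c1O` gives 237 nM, compound 2 `Cc1c(OCCCCOc2cccc(C(=O)O)c2)ccc(C(=O)CC2CCCC2)c1O` gives 451 nM, and compound 3 `CCC(=O)c1ccc(OCCCCOc2ccc(C(=O)O)cc2C)c(C)c1O` gives 82 nM. Compound 3 therefore stands with the lowest number of the three; its nearest neighbour is compound 1, and compound 2 lies furthest away, both beyond the scatter.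

Compound 4 `Cc1cc(C(=O)O)ccc1OCCCCOc1ccc(C(=O)CC2CCCC2)c(O)c1C` is derived from compound 3 by a single change: cyclopentyl in place of methyl on a saturated chain carbon bound to a carbonyl carbon. Among the measured compounds shown here, the only measured step, a 1.9-fold higher number from compound 1 to compound 2 (0.28 log units; within the scatter), concerns the oxygen-linked carboxyphenyl group and not the chain next to the carbonyl, so it does not bear on this change. Compound 1 and compound 2 already carry the cyclopentyl group that enters here, and their numbers in this assay are higher than that of compound 3, but they differ from compound 3 in the carboxyphenyl part as well, so no clean comparison exists.

The expectation for compound 4 is therefore cautious: a modest rise in the number, a 1.7-fold higher number from compound 3 to compound 4 (0.23 log units; within the scatter), with the range allowing for no change beyond the scatter. Compound 4 is estimated at 140 nM, between 55 nM and 360 nM.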

Compound 4, half-maximal effective concentration: 608 nM
Beside the measured number, compound 4's estimate is 4.3-fold (0.64 log units) below it; the measured number lies above the stated range.
By their numbers in this assay, from the lowest: compound 3; then compounds 1, 2 and 4 (each within the scatter of the next, the first and the last beyond it).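

In this assay, among the compounds shown here, the step of a 7.4-fold higher number from compound 3 to compound 4 (0.87 log units; beyond the scatter) is the first reading of this position with the rest of the molecule held fixed: going from methyl, one heavy atom, to cyclopentyl, five heavy atoms in a five-membered ring of carbon, on a saturated chain carbon bound to a carbonyl carbon raises the number beyond the scatter. With cyclopentyl held in place, the aromatic end can now be read as well: the step of a 2.6-fold higher number from compound 1 to compound 4 (0.41 log units; beyond the scatter) comes with methyl in place of chloro on an aromatic carbon and lies beyond the scatter, while the step of a 1.3-fold higher number from compound 2 to compound 4 (0.13 log units; within the scatter) stays within it, so 4-carboxy-2-methylphenyl and 3-carboxyphenyl cannot be told apart in this cyclopentyl setting. No measurement shown here explains why the change at the chain has this effect.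

The compounds shown give only the two ends of this change, methyl and cyclopentyl, so it remains open whether the number climbs gradually or abruptly with an intermediate group such as isopropyl, or how a phenyl ring would fare at the same place. As far as these compounds go, it is also open whether the chloro and methyl groups on the aromatic carbon would differ in the same way when methyl rather than cyclopentyl sits on the chain.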